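Thioamide to N-ethyl thioamide on a pyridazinone side chain

The compounds below may be only part of what the source reports. "The series", "measured", "known", "first", "only" and "open" are said of these compounds alone.

Compound 1, with structure `N=C(S)CCCn1nc(-c2ccccc2)ccc1=O`, is tested in a functional assay on the whole organism (stomach) for inhibition, with Rattus norvegicus as the target, at a dose of 100 mg/kg by the intraduodenal route (a lower number here means less inhibition, a higher number more inhibition at the dose given (going by the name of the read-out)), where compound 1 gives 75.6%, the higher of the two numbers measured. Compound 2, with structure `N=C(S)CCn1nc(-c2ccccc2)ccc1=S`, reaches 62.3% in this assay. Compound 3, with structure `CC/N=C(\S)CCn1nc(-c2ccccc2)ccc1=O`, is not yet measured. It differs from compound 1 by a group of 5 heavy atoms (3 carbon, 1 nitrogen, 1 sulfur; no ring) in place of a group of 4 heavy atoms (2 carbon, 1 nitrogen, 1 sulfur; no ring), on a saturated chain carbon, two bonds along the chain from an aromatic nitrogen. For the measured compounds named here, with no measured pair showing such a change, only a guess is possible: a modest downward step is expected from compound 1 to compound 3, about a number 13.6 percentage points lower from compound 1 to compound 3 (beyond the scatter). Compound 3 is therefore expected to give about 62%, within a range of 42% to 80%.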

Compound 3, a percentage reported as inhibition, in the whole organism at one dose (the size of the read-out at that dose, not a potency): 50.3%
For compound 3 the middle estimate is 11.7 percentage points above the measured one; measured number inside the range.
By their numbers in this assay, from the lowest: compound 3; then compound 2; then compound 1.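

In this assay, the swap on a saturated chain carbon, two bonds along the chain from an aromatic nitrogen, gives a number 25.3 percentage points lower from compound 1 to compound 3 (beyond the scatter). For the compounds shown here, this is the first step measured at this place, and it shows that the read-out responds to the change, with the entering group counting one hydrogen-bond donor where the leaving group counts two. Nothing measured here gives a reason for the drop. The compounds shown leave open how an amine or a carboxylic acid at this place would perform.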